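This account rests on a few compounds, and the source may have more. Where it says the series, first, only, none or still open, it means among the compounds named here.

Measured in a functional assay on K562 cells (Homo sapiens), read by MTT assay, with a stated time of 72 h; on this read-out lower numbers stand for stronger inhibition and higher numbers for weaker inhibition:
- compound 1 `CSc1ncnc2c1c(-c1ccoc1)cn2[C@@H]1O[C@H](CO)[C@@H](O)[C@H]1O`: 3250 nM
- compound 2 `CNc1ncnc2c1c(-c1ccco1)cn2[C@@H]1O[C@H](CO)[C@@H](O)[C@H]1O`: 15100 nM
- compound 3 `CNc1ncnc2c1c(-c1ccoc1)cn2[C@@H]1O[C@H](CO)[C@@H](O)[C@H]1O`: > 20000 nM (a limit)

Compound 3 stands at > 20000 nM in this assay, which is a limit and not a number. Compound 4 `CNc1ncnc2c1c(-c1ccsc1)cn2[C@@H]1O[C@H](CO)[C@@H](O)[C@H]1O` differs from it in one place: thiophen-3-yl in place of furan-3-yl on an aromatic carbon. The nearest measured change, furan-3-yl in place of furan-2-yl, gives an at least 1.3-fold higher number from compound 2 to compound 3 (0.12 log units; that floor lies within the scatter), a floor within the scatter. The other measured change, methylamino in place of methylsulfanyl, gives an at least 6.1-fold higher number from compound 1 to compound 3 (0.78 log units; beyond the scatter), which is beyond the scatter but lies elsewhere on the shared core. No step beyond the scatter is therefore expected in this assay, and no direction can be favoured. The expected step is an at least 1.2-fold lower number from compound 3 to compound 4 (0.09 log units; that floor lies within the scatter). For compound 4 the estimate is 16000 nM, with an expected range from 6000 nM to 35000 nM.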

Compound 4, half-maximal inhibitory concentration: > 20000 nM
Compound 4 was reported as a limit; the forecaster's own chance of this, stated with the estimate: 50%; middle value at least 1.2-fold (0.09 log units) away from the limit.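

In this assay compound 4, which carries thiophen-3-yl at this position, gives only a limit, and compound 3, which carries furan-3-yl, does too: the limit of > 20000 nM in this assay, at which 2 of the 4 values shown sit. The step between these two compounds cannot be read, so exchanging furan-3-yl for thiophen-3-yl brings no readable value alongside methylamino. The comparison with furan-2-yl gives an at least 1.3-fold higher number from compound 2 to compound 4 (0.12 log units; that floor lies within the scatter), so no order between those two compounds can be claimed.

As far as these compounds go, it remains open whether thiophen-3-yl would give a readable value alongside methylsulfanyl, the group of compound 1. Also open, from the compounds shown here alone, is how a phenyl ring or a simple amine would behave at this position.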